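The compounds below may be only part of what the source reports. "The series", "measured", "known", "first", "only" and "open" are said of these compounds alone.

Compound 3 `O=C(Nc1cc2c(Nc3ccc(F)c(Cl)c3)ncnc2cc1O[C@H]1CCOC1)N1CCC(F)(F)CC1` gives the highest number of the three in a functional assay on A-431 cells (Homo sapiens) for antiproliferative activity, read by sulforhodamine B assay, with a stated time of 72 h (on this read-out lower numbers stand for stronger inhibition and higher numbers for weaker inhibition), at 1860 nM. Compound 1 `CN(C)CCCNC(=O)Nc1cc2c(Nc3ccc(F)c(Cl)c3)ncnc2cc1O[C@H]1CCOC1` gives 226 nM and compound 2 `CN(C)CCCN(C)C(=O)Nc1cc2c(Nc3ccc(F)c(Cl)c3)ncnc2cc1O[C@H]1CCOC1` gives 200 nM in this assay, so the step of an 8.2-fold higher number from compound 1 to compound 3 (0.92 log units; beyond the scatter) and the step of a 9.3-fold higher number from compound 2 to compound 3 (0.97 log units; beyond the scatter) both run toward weaker inhibition. Compound 4 `O=C(Nc1cc2c(Nc3ccc(F)c(Cl)c3)ncnc2cc1O[C@H]1CCOC1)N1CCC(CCO)CC1` differs from compound 3 by 4-(2-hydroxyethyl)piperidin-1-yl in place of 4,4-difluoropiperidin-1-yl on a carbonyl carbon. Among the measured compounds shown here, no measured step swaps one piperidine for another; the two steps that end at compound 3 only show that a ring in place of the open chain brought a modest loss. Compound 4 is therefore expected to stay close to compound 3, with a step of about a 1.6-fold lower number from compound 3 to compound 4 (0.19 log units; within the scatter). The estimate for compound 4 is 1200 nM, between 400 nM and 4000 nM.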

Compound 4, half-maximal inhibitory concentration: 759 nM
Compound 4: the middle estimate sits 1.6-fold (0.20 log units) above what was measured; low and high end bracket the measured number.
By their numbers in this assay, from the lowest: compounds 2 and 1 (each within the scatter of the next); then compound 4; then compound 3.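

On this carbonyl carbon, one piperidine can be exchanged for another with a result beyond the scatter: 4-(2-hydroxyethyl)piperidin-1-yl in place of 4,4-difluoropiperidin-1-yl gives a 2.5-fold lower number from compound 3 to compound 4 (0.39 log units; beyond the scatter). The open chains still give lower numbers, with a 3.4-fold higher number from compound 1 to compound 4 (0.53 log units; beyond the scatter) and a 3.8-fold higher number from compound 2 to compound 4 (0.58 log units; beyond the scatter), so this ring closes only part of the gap. Nothing measured here explains the difference between the two rings. From the compounds shown here alone, whether a piperidine carrying an amine, such as 4-(dimethylamino)piperidin-1-yl, would close the remaining gap stays open.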